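Removing a phenyl from compound 2: a limit stays a limit

A few compounds are considered here, and "the series" means these few. Any claim that something is new, unique, unknown or untested is made for them only; others in the source may bear on it.

The measured compounds, each with its result in an assay on isolated protein for inhibition of thyroid hormone receptor alpha (Homo sapiens), read by fluorescence polarization; a lower number here means a stronger inhibitor, a higher number a weaker inhibitor:
compound 1 `CN(Cc1cccc(F)c1)C(=O)CNC(=O)c1ccc(S(C)(=O)=O)c([N+](=O)[O-])c1`, a limit only: > 60000 nM
compound 2 `CS(=O)(=O)c1ccc(C(=O)N2CCC(C(=O)N(Cc3ccccc3)Cc3ccccc3)CC2)cc1[N+](=O)[O-]`, a limit only: > 60000 nM
compound 3 `CS(=O)(=O)c1ccc(C(=O)NCCCC(=O)N2CCCCC2)cc1[N+](=O)[O-]`, a limit only: > 60000 nM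

Compound 2 stands where every compound shown stands: the limit of > 60000 nM in this assay, at which 3 of the 3 values shown sit. No numerical value exists for compound 2 in this assay, only the limit, and the same holds for compound 1 and compound 3. Among the compounds with values here, with three limits and no numbers, no step between measured compounds can be sized, and nothing shows whether any change to this shared core moves the read-out at all.

Compound 4 `CN(Cc1ccccc1)C(=O)C1CCN(C(=O)c2ccc(S(C)(=O)=O)c([N+](=O)[O-])c2)CC1` is not yet measured. It differs from compound 2 in one place, (hydrogen in place of phenyl on a saturated chain carbon bound to an amide-type nitrogen). The rest of compound 2, including the piperidine-bearing part and its sulfonyl-nitro aryl amide, is kept unchanged.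

Whether this step produces a measurable number is unknown from what is shown. The expectation for compound 4 rests only on the three limits: it is estimated to remain at or beyond the limit, so the step that the limit leaves unreadable from compound 2 to compound 4 is expected to be none beyond the scatter. For compound 4 the estimate in this assay is 100000 nM, with a range from 30000 nM to 400000 nM.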

Compound 4, half-maximal inhibitory concentration: > 60000 nM
Compound 4: no number, only a limit; the forecaster's own chance of this, stated with the estimate: 85%; the middle value lies beyond the limit too.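

In this assay compound 4 gives > 60000 nM, which is a limit and not a number. Compound 2 also has only a limit, so no step can be read between compound 2 and compound 4. The compounds shown leave open whether any change to the shared core can bring a measurable value in this assay.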